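This account rests on a few compounds, and the source may have more. Where it says the series, first, only, none or still open, it means among the compounds named here.

Measured in a functional assay on HL-60 cells (Homo sapiens) for cytotoxicity, read by WST assay, with a stated time of 48 h; on this read-out lower numbers stand for an effect already at smaller amounts and higher numbers for an effect only at larger amounts of compound:
- compound 1 `Fc1ccccc1C[C@H]1COC[C@@H]1Cc1ccc(Cl)c(Cl)c1`: 51000 nM
- compound 2 `Cc1cccc(C[C@H]2COC[C@@H]2Cc2ccc(Cl)c(Cl)c2)c1`: 28000 nM

With only these two numbers, compound 2 cannot be separated from compound 1, and the two values lie within the scatter of each other. Compound 3 `Oc1ccc(C[C@H]2COC[C@@H]2Cc2ccc(Cl)c(Cl)c2)cc1` has 4-hydroxyphenyl in place of 3-methylphenyl on a saturated chain carbon bound to a saturated ring carbon. Among the compounds with values here, only one measured step bears on this change: a 1.8-fold lower number from compound 1 to compound 2 (0.26 log units; within the scatter). It exchanges the group at the same place, and its size stays within the scatter. Within the data shown here, no measured compound carries 4-hydroxyphenyl, so that step is only a weak guide. No step beyond the scatter is therefore expected in this assay, and no direction can be favoured. The expected outcome is a 1.1-fold higher number from compound 2 to compound 3 (0.03 log units; within the scatter). For compound 3 the estimate is 30000 nM, with an expected range from 10000 nM to 70000 nM.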

Compound 3, half-maximal effective concentration: 31000 nM
Estimate against measurement, compound 3: 1.0-fold (0.01 log units) below; the range from low to high includes it.
By their numbers in this assay, from the lowest: compounds 2, 3 and 1 (each within the scatter of the next).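

In this assay, 4-hydroxyphenyl in place of 3-methylphenyl adds a hydrogen-bond donor and a hydrogen-bond acceptor on a saturated chain carbon bound to a saturated ring carbon, yet the step stays within the scatter: a 1.1-fold higher number from compound 2 to compound 3 (0.04 log units; within the scatter). The exchange for 2-fluorophenyl reads the same, with a 1.6-fold lower number from compound 1 to compound 3 (0.22 log units; within the scatter), so the three groups shown at this place cannot be separated in this read-out. No accompanying measurement bears on the interpretation of these steps.

As far as these compounds go, whether a non-aromatic group at this place, such as an amine or a carboxylic acid on a longer chain, would give a step beyond the scatter remains open. Also open, from the compounds shown here alone, is whether a change elsewhere on the shared core, which is the same in all three compounds, would separate their numbers.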